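This account rests on a few compounds, and the source may have more. Where it says the series, first, only, none or still open, it means among the compounds named here.

In an ADME assay on MT4 cells (Homo sapiens) for cytotoxicity, read by MTT assay (a lower number here means that less compound is tolerated, a higher number that more compound is tolerated), compound 1 `CCS(=O)(=O)N1CCN(Cc2ccc(Nc3nccc(Oc4c(C)cc(/C=C/C#N)cc4C)n3)cc2)CC1` gives 4600 nM. Two companions share its core: compound 2 `Cc1cc(C#N)cc(C)c1Oc1ccnc(Nc2ccc(CN3CCCN(S(=O)(=O)N(C)C)CC3)cc2)n1` gives 4190 nM in this assay, and compound 3 `Cc1cc(C#N)cc(C)c1Oc1ccnc(Nc2ccc(CN3CCN(S(=O)(=O)C(C)C)CC3)cc2)n1` gives 4540 nM. The number for compound 1 is the largest of the three, yet its gaps to compound 3 and to compound 2 both lie within the scatter, so the three read as a single level. Compound 4 `Cc1cc(/C=C/C#N)cc(C)c1Oc1ccnc(Nc2ccc(CN3CCCN(S(C)(=O)=O)CC3)cc2)n1` has not yet been measured. It differs from compound 1 by 4-(methylsulfonyl)-1,4-diazepan-1-yl in place of 4-(ethylsulfonyl)piperazin-1-yl on a saturated chain carbon bound to an aromatic carbon. The three measured compounds, carrying different ring groups at that position, sit at one level; on that basis no step beyond the scatter is expected from compound 1 to compound 4. The estimate for compound 4 is 4500 nM, with a range from 2300 nM to 9000 nM, meaning an expected step of a 1.0-fold lower number from compound 1 to compound 4 (0.01 log units; within the scatter).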

Compound 4, half-maximal cytotoxic concentration: 17400 nM
Compound 4: the middle estimate sits 3.9-fold (0.59 log units) below what was measured, and the stated range ends below it.
By their numbers in this assay, from the lowest: compounds 2, 3 and 1 (each within the scatter of the next); then compound 4.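

The earlier compounds shown here showed no spread, but this position can move the number in this assay: 4-(methylsulfonyl)-1,4-diazepan-1-yl in place of 4-(ethylsulfonyl)piperazin-1-yl gives a 3.8-fold higher number from compound 1 to compound 4 (0.58 log units; beyond the scatter) with the heavy-atom count unchanged. Nothing available bears on why the number rises. The change alters both ring size and sulfonyl chain, and the compounds shown leave open which of the two carries the step. A 4-(methylsulfonyl)piperazin-1-yl or 4-(ethylsulfonyl)-1,4-diazepan-1-yl group at the same place would separate them.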